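Swapping a Butylamide for a Pyrrolidine Amide

The source may report more compounds than this note shows. Statements on the series, on what has been measured and on what is new or still open speak of the compounds shown alone.

Compound 1 `COc1cc2c(cc1OC)C(CC(=O)O)CC2`: 23.9%
Compound 2 `CCCCNC(=O)CC1CCc2cc(OC)c(OC)cc21`: 25%

In a functional assay on the whole organism (strain Wistar) for inhibition, with Rattus norvegicus as the target, read by paw edema, with stated times of 60 min and 4 h, at a dose of 100 mg/kg by the oral route (on this read-out lower numbers stand for less inhibition and higher numbers for more inhibition at the one dose given (going by the name of the read-out)), compound 1 gives 23.9% and compound 2 gives 25%. Compound 2 sits at one end of this pair of numbers, yet the step of a number 1.1 percentage points higher from compound 1 to compound 2 (within the scatter) lies within the scatter, so the two compounds cannot be told apart on these figures.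

Compound 3 `COc1cc2c(cc1OC)C(CC(=O)N1CCCC1)CC2` has not yet been measured. It differs from compound 2 by the change (pyrrolidin-1-yl in place of butylamino on a carbonyl carbon). For the measured compounds named here, the only measured step at that same carbonyl carbon, a number 1.1 percentage points higher from compound 1 to compound 2 (within the scatter), stayed within the scatter, and no other measured pair bears on this change. The data therefore give no ground to expect movement, and the expected step is no change at the digits printed from compound 2 to compound 3 (within the scatter), that is, nothing beyond the scatter. Compound 3 is thus estimated at 25%, with a range from 12% to 38%.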

Compound 3, a percentage reported as inhibition, in the whole organism at one dose (the size of the read-out at that dose, not a potency): 24.2%
Compound 3: the middle estimate sits 0.8 percentage points above what was measured; measured number inside the range.
By their numbers in this assay, from the lowest: compounds 1, 3 and 2 (each within the scatter of the next).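

In this assay, pyrrolidin-1-yl in place of butylamino on a carbonyl carbon gives a number 0.8 percentage points lower from compound 2 to compound 3 (within the scatter), so the number holds when the open chain gives way to a ring and the one hydrogen-bond donor of butylamino is gone. The comparison with the free acid gives a number 0.3 percentage points higher from compound 1 to compound 3 (within the scatter), which means that hydroxy, butylamino and pyrrolidin-1-yl on this carbonyl carbon cannot be told apart on these figures. No measurement shown here offers an explanation for this lack of separation.

On these data alone, whether any group at this carbonyl carbon can move the number beyond the scatter remains open. A benzylamino group, a morpholin-4-yl group or a methyl ester would each test this further, as would a longer chain between the carbonyl and the shared core.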